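A few compounds are considered here, and "the series" means these few. Any claim that something is new, unique, unknown or untested is made for them only; others in the source may bear on it.

Measured compounds:
- compound 1, `COc1ccc(C(=O)/C=C/c2ccc(OCCNc3ccnc4cc(Cl)ccc34)c(OC)c2)c(OC)c1`: 0.292 h
- compound 2, `COc1ccc(C(=O)/C=C/c2ccc(O)c(CN3CCN(c4ccnc5cc(Cl)ccc45)CC3)c2)c(OC)c1`: 0.977 h
- compound 3, `COc1cc(/C=C/C(C)=O)ccc1OCc1cn(-c2ccnc3cc(Cl)ccc23)nn1`: 0.123 h

In an in vitro ADME assay on microsomes from liver (Homo sapiens) for metabolic stability, read by LC-MS, using NADPH, tested at 1 uM, in the presence of a further agent that is not named here (on this read-out higher numbers stand for a longer-lived compound and lower numbers for a shorter-lived compound), compound 2 gives the highest of the three numbers. Its nearest neighbour is compound 1, whose value of 0.292 h sits beyond the scatter below it, and compound 3 with 0.123 h lies furthest away. For the measured compounds named here, none of these three pairs differ in one place only, so the numbers are read side by side and no single step is drawn from them.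

Compound 4, `COc1ccc(C(=O)/C=C/c2cc(CN3CCN(c4ccnc5cc(Cl)ccc45)CC3)c(O)c(OC)c2)c(OC)c1`, differs from compound 2 by methoxy in place of hydrogen on an aromatic carbon. Going by the values given here, no measured pair shows what such a change does in this assay, so the expectation rests only on the value of compound 2, 0.977 h, and the change is taken to shift that number little, if at all, beyond the scatter. The expected step is a 1.2-fold lower number from compound 2 to compound 4 (0.09 log units; within the scatter), with no firm direction. For compound 4 the estimate in this assay is 0.8 h, within a range from 0.35 h to 1.8 h.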

Compound 4, half-life in the Homo sapiens assay: 0.617 h
Beside the measured number, compound 4's estimate is 1.3-fold (0.11 log units) above it, within the range that was stated.
By their numbers in the Homo sapiens assay, from the lowest: compound 3; then compound 1; then compounds 4 and 2 (each within the scatter of the next).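

For the compounds shown here, in the Homo sapiens assay compound 2 (0.977 h) and compound 4 (0.617 h) differ by the methoxy on an aromatic carbon, ortho to a hydroxy group and meta to two large groups, which gives the first step that can be read at a single place (a 1.6-fold lower number from compound 2 to compound 4 (0.20 log units; within the scatter)), so this position takes the methoxy without a shift that clears the scatter. In a physicochemical assay for lipophilicity, read by HPLC, at pH 7.4 (a higher number here means a more lipophilic compound, a lower number a more polar compound), compound 2 (5.3) and compound 4 (5) show the same change also staying inside the scatter (a number 0.30 log units lower from compound 2 to compound 4 (within the scatter)). Nothing on hand accounts for either reading.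

The compounds shown leave open whether another group at this place, such as an ethoxy, a longer chain, an amine or a carboxylic acid, would move either number beyond the scatter. They also leave open whether a methoxy on the other aromatic carbons of this ring would read the same way.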